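Notes on the amide-nitrogen group change towards compound 4

The compounds below may be only part of what the source reports. "The series", "measured", "known", "first", "only" and "open" are said of these compounds alone.

In a physicochemical assay for lipophilicity, at pH 7.4 (a lower number here means a more polar compound, a higher number a more lipophilic compound), compound 2 (`CS(=O)(=O)N1C[C@H](C(=O)Nc2ccc(Cl)cn2)[C@@H](C(=O)Nc2ccc(-n3ccccc3=O)cc2F)C1`) gives 1.46 and sits second highest of three numbers. Compound 1 (`NS(=O)(=O)N1C[C@H](C(=O)Nc2ccc(Cl)cc2)[C@@H](C(=O)Nc2ccc(-n3ccccc3=O)cc2F)C1`) stands higher (1.83) and compound 3 (`O=C(Nc1ccc(Cl)cn1)[C@H]1CNC[C@@H]1C(=O)Nc1ccc(-n2ccccc2=O)cc1F`) lower (0.63).

Compound 4 (`COc1ccc(NC(=O)[C@H]2CN(S(C)(=O)=O)C[C@@H]2C(=O)Nc2ccc(-n3ccccc3=O)cc2F)cc1F`) carries 3-fluoro-4-methoxyphenyl in place of 5-chloropyridin-2-yl on an amide-type nitrogen and is otherwise the same as compound 2.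

Among the compounds with values here, the only measured single-place step is a number 0.83 log units lower from compound 2 to compound 3 (beyond the scatter) and it concerns hydrogen in place of methylsulfonyl on an amine nitrogen in a ring. It therefore says nothing direct about this change. Compound 1 differs from compound 2 in more than one place, so its gap is not read as a step. Within the data shown here, no measured step covers the amide-type nitrogen, so the expectation stays anchored on compound 2 (1.46) with no shift beyond the scatter in this assay expected.

The estimated change is a number 0.06 log units lower from compound 2 to compound 4 (within the scatter) and this is a weakly supported figure. Compound 4 is expected at 1.4 with an estimated range from 1 to 1.8 for now.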

Compound 4, distribution coefficient: 0.56
Compound 4: middle estimate off by 0.84 log units, on the high side; the whole stated range lies above it.
By their numbers in this assay, from the lowest: compounds 4 and 3 (each within the scatter of the next); then compound 2; then compound 1.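

In this assay the place on the amide-type nitrogen proves responsive: 3-fluoro-4-methoxyphenyl in place of 5-chloropyridin-2-yl gives a number 0.90 log units lower from compound 2 to compound 4 (beyond the scatter) with the rest of the structure unchanged. Within the data shown here, until this result the only single-place step concerned the amine nitrogen in the ring, so this is the first direct reading at the amide-type nitrogen. No available evidence accounts for the size of this step or assigns it to any part of the two groups.

This single exchange alters the ring atoms and the substituents together, so the shares of the chlorine, the ring nitrogen, the fluorine and the methoxy group cannot be separated. As far as these compounds go, how an unsubstituted phenyl, or a phenyl carrying only the methoxy group or a carboxylic acid, would read at this place remains open.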